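From a Methylphenyl Ester to an Oxazole Ester

The compounds below may be only part of what the source reports. "The series", "measured", "known", "first", "only" and "open" are said of these compounds alone.

Three compounds have been measured in an ADME assay on a cell-free system (plasma, Homo sapiens) for metabolic stability, with Plasma (Rattus norvegicus) as the target, read by HPLC, at pH 7.4; on this read-out higher numbers stand for a longer-lived compound and lower numbers for a shorter-lived compound:

Compound 1 `CC(=O)Oc1ccccc1C(=O)O[C@H]1CO[C@H]2[C@@H]1OC[C@H]2OC(=O)c1ccnn1C` gives 0.0642 h.
Compound 2 `CCCCC(=O)O[C@@H]1CO[C@H]2[C@@H]1OC[C@@H]2OC(=O)c1ccccc1OC(C)=O` gives 0.0117 h.
Compound 3 `CC(=O)Oc1ccccc1C(=O)O[C@H]1CO[C@H]2[C@@H]1OC[C@H]2OC(=O)c1ccc(C)cc1` gives 0.0362 h.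

All three share the same core and differ only in the group on one carbonyl carbon. Compound 3 is separated from compound 1 by a 1.8-fold lower number from compound 1 to compound 3 (0.25 log units; within the scatter), so the two cannot be told apart, while a 3.1-fold higher number from compound 2 to compound 3 (0.49 log units; beyond the scatter) sets compound 3 clearly apart from compound 2.

Compound 4 `CC(=O)Oc1ccccc1C(=O)O[C@H]1CO[C@H]2[C@@H]1OC[C@H]2OC(=O)c1cnoc1C` is not yet measured. It differs from compound 3 as follows: 5-methyl-1,2-oxazol-4-yl in place of 4-methylphenyl on a carbonyl carbon

The step that bears most on this is a 1.8-fold lower number from compound 1 to compound 3 (0.25 log units; within the scatter): a five-membered aromatic ring with 2 hetero atoms in place of 4-methylphenyl changed nothing beyond the scatter. Compound 4 brings in another such ring, so no step beyond the scatter is expected. The step from compound 3 to compound 4 is estimated as a 1.2-fold higher number from compound 3 to compound 4 (0.09 log units; within the scatter). Compound 4 is therefore expected to give about 0.045 h, between 0.02 h and 0.1 h.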

Compound 4, half-life: 0.001 h
Estimate against measurement, compound 4: 45-fold (1.65 log units) above, and the stated range ends above it.
By their numbers in this assay, from the lowest: compound 4; then compound 2; then compounds 3 and 1 (each within the scatter of the next).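

The group on this carbonyl carbon can matter far more in this assay than the first three compounds showed: 5-methyl-1,2-oxazol-4-yl in place of 4-methylphenyl gives a 36-fold lower number from compound 3 to compound 4 (1.56 log units; beyond the scatter). A five-membered aromatic ring with 2 hetero atoms therefore does not settle the outcome by itself, since the two such rings here, 1-methyl-1H-pyrazol-5-yl and 5-methyl-1,2-oxazol-4-yl, are far apart, with a 64-fold lower number from compound 1 to compound 4 (1.81 log units; beyond the scatter). Within the data shown here, compound 4 also falls well under the butyl ester, the shortest-lived of the earlier compounds, with a 12-fold lower number from compound 2 to compound 4 (1.07 log units; beyond the scatter), which makes compound 4 the shortest-lived of all four.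

Nothing available explains why this one ring behaves so differently from the others. On these data alone, it also remains open whether a 1,2-oxazol-4-yl ring with no methyl, or a plain phenyl, would fall near compound 4 or near compound 3.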